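The source may report more compounds than this note shows. Statements on the series, on what has been measured and on what is new or still open speak of the compounds shown alone.

The series shares a triazole core carrying an aryl group and a substituent on the ring nitrogen. Compound 1 `CC1(C)OCC(Cn2cc(-c3ccc(C(F)(F)F)cc3)nn2)O1` gives, in a functional assay on B16 cells (Mus musculus) for cytotoxicity, read by MTT assay, with a stated time of 48 h (on this read-out lower numbers stand for stronger inhibition and higher numbers for weaker inhibition), a measured value of 13500 nM. Compound 2 `COc1cccc(Cn2cc(-c3ccc4ccccc4c3)nn2)c1` reaches in this assay only the limit of the measurement, > 100000 nM. Compound 3 `Cc1ccc(C(O)c2cn(CC3COC(C)(C)O3)nn2)cc1` likewise reaches in this assay only a limit, > 100000 nM. So compound 3 stands where no number is known for it, and it shares that position with compound 2, which is the situation described by the limit of > 100000 nM in this assay, at which 2 of the 3 values shown sit; compound 1 alone returns a number within the measured range.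

Compound 4 `Cc1ccc(C(O)c2cn(Cc3ccccc3)nn2)cc1` differs from compound 3 in one place: phenyl in place of 2,2-dimethyl-1,3-dioxolan-4-yl on a saturated chain carbon bound to an aromatic nitrogen. Among the compounds with values here, no measured pair in the set makes this same change, so the size of the step has to be judged from the surrounding compounds. Compound 2, which carries a benzyl-type group on the ring nitrogen, sits at the limit in this assay, and compound 3 sits there as well, which leaves little room to expect a gain. The step from compound 3 to compound 4 is therefore expected to be small or none beyond the scatter, an at least 1.2-fold lower number from compound 3 to compound 4 (0.09 log units; that floor lies within the scatter). For compound 4 the estimate in this assay is 80000 nM, with a range from 20000 nM to 300000 nM, and a fair chance that only a limit is reported again.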

Compound 4, half-maximal inhibitory concentration: > 100000 nM
Compound 4 gave a limit, no number (the forecaster's own chance of this, stated with the estimate: 55%); middle value at least 1.2-fold (0.09 log units) away from the limit.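

Compound 3 and compound 4 both return only a limit in this assay, so no step between them can be read, and the result adds one more compound to those at the limit: the limit of > 100000 nM in this assay, at which 3 of the 4 values shown sit.

The compounds shown leave open whether phenyl in place of 2,2-dimethyl-1,3-dioxolan-4-yl changes the read-out at all.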